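Methyl in place of fluoro on a shared core

The compounds below may be only part of what the source reports. "The series", "measured", "known", "first", "only" and "open" are said of these compounds alone.

compound 1 `O=C(Nc1ccc(-n2ncc3c(C(F)(F)F)cccc32)cc1)Nc1ccc(Cl)c(C(F)(F)F)c1` — 2000 nM
compound 2 `O=C(Nc1ccc(-n2ncc3c(F)cccc32)cc1)Nc1ccc(Cl)c(C(F)(F)F)c1` — 3100 nM

In a functional assay on MDA-MB-231 cells (Homo sapiens) for cytotoxicity, read by MTT assay, with a stated time of 72 h (a higher number here means a weaker inhibitor, a lower number a stronger inhibitor), compound 1 gives 2000 nM and compound 2 gives 3100 nM. For the measured compounds named here, compound 2 carries the higher of the two numbers, but its only neighbour, compound 1, lies within the scatter of it: a 1.6-fold higher number from compound 1 to compound 2 (0.19 log units; within the scatter). Compound 3 `Cc1cccc2c1cnn2-c1ccc(NC(=O)Nc2ccc(Cl)c(C(F)(F)F)c2)cc1` has not been measured. It differs from compound 2 by methyl in place of fluoro on an aromatic carbon. Going by the values given here, the one measured step at this same site, a 1.6-fold higher number from compound 1 to compound 2 (0.19 log units; within the scatter), stayed within the scatter, so for compound 3 in this assay no step beyond the scatter is expected: a 1.0-fold lower number from compound 2 to compound 3 (0.01 log units; within the scatter). Compound 3 is therefore estimated at 3000 nM, with a range from 1200 nM to 7500 nM.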

Compound 3, half-maximal inhibitory concentration: 2300 nM
Compound 3: the middle estimate sits 1.3-fold (0.12 log units) above what was measured; measured number inside the range.
By their numbers in this assay, from the lowest: compounds 1, 3 and 2 (each within the scatter of the next).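

In this assay, methyl in place of fluoro gives a 1.3-fold lower number from compound 2 to compound 3 (0.13 log units; within the scatter) and methyl in place of trifluoromethyl gives a 1.2-fold higher number from compound 1 to compound 3 (0.06 log units; within the scatter) so all three groups at this aromatic carbon now lie within the scatter of one another. This position has thus taken a third group without a step beyond the scatter in this assay. No evidence is at hand that bears on this result. The compounds shown leave open whether an amine, a carboxylic acid or a longer chain at this position would give a step beyond the scatter.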